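Extending the saturated chain from compound 2 to compound 3

A few compounds are considered here, and "the series" means these few. Any claim that something is new, unique, unknown or untested is made for them only; others in the source may bear on it.

In a functional assay on MCF7 cells (Homo sapiens) for inhibition, with a stated time of 48 h, tested at 50 uM (on this read-out lower numbers stand for less inhibition of growth and higher numbers for more inhibition of growth at the one concentration tested), compound 1 `C=C[C@@](C)(/C=C/c1ccc(OC(=O)CCCCC)cc1)CCC=C(C)C` gives 18% and compound 2 `C=C[C@@](C)(/C=C/c1ccc(OC(=O)CCCCCCCCC)cc1)CCC=C(C)C` gives 10%. Compound 2 therefore stands within the scatter of compound 1, and no other measured number is available for comparison. Compound 3 `C=C[C@@](C)(/C=C/c1ccc(OC(=O)CCCCCCCCCCCCCCC)cc1)CCC=C(C)C` differs from compound 2 by hexyl in place of hydrogen on a saturated chain carbon, nine bonds along the chain from a carbonyl carbon. Among the compounds with values here, the only measured step bearing on this change is a number 8 percentage points lower from compound 1 to compound 2 (within the scatter), which also extends the saturated chain, with butyl in place of hydrogen on a saturated chain carbon, five bonds along the chain from a carbonyl carbon. A single step within the scatter establishes no trend, so no step beyond the scatter is expected in this assay. The expected step is a number 2 percentage points lower from compound 2 to compound 3 (within the scatter). The estimated value for compound 3 is 8%, with an expected range of 0% to 18%.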

Compound 3, percent growth inhibition at one concentration: 24%
Compound 3: middle estimate off by 16 percentage points, on the low side; measured number outside the range, above it.
By their numbers in this assay, from the lowest: compounds 2, 1 and 3 (each within the scatter of the next, the first and the last beyond it).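

In this assay, within the data shown here, the longer chain gives the first step beyond the scatter: a number 14 percentage points higher from compound 2 to compound 3 (beyond the scatter) when hexyl replaces hydrogen on a saturated chain carbon, nine bonds along the chain from a carbonyl carbon. Extension at this chain therefore does not simply lower the number, and only compound 2 and compound 3 are separated, since a number 6 percentage points higher from compound 1 to compound 3 (within the scatter) leaves the shortest and longest chains shown indistinguishable. Nothing measured here bears on what lies behind this step.

As far as these compounds go, whether a still longer chain would keep the number at the level of compound 3 or shift it again remains open. Also open, from the compounds shown here alone, is how an amine or a carboxylic acid at the chain end would read at this single concentration.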